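The source may hold more compounds than are shown below. What is called first, only, known or untested is meant among the compounds shown, and "the series" means these compounds.

Compound 1 `CCNc1cc(-c2ccc(NC(=O)Nc3ccc(OC)cc3)cc2OC)ccn1`: > 30000 nM, a limit
Compound 2 `CCNc1cc(-c2ccc(NC(=O)Nc3ccc(C(F)(F)F)cc3)cc2OC)ccn1`: 25600 nM
Compound 3 `CCNc1cc(-c2ccc(NC(=O)Nc3c(C)cccc3C)cc2OC)ccn1`: > 30000 nM, a limit

In a functional assay on BT-483 cells (Homo sapiens) for cytotoxicity, read by MTT assay, with a stated time of 24 h (on this read-out lower numbers stand for stronger inhibition and higher numbers for weaker inhibition), compound 1 gives > 30000 nM. That is a limit of the assay and not a number. It is also a common result in this small set, with the limit of > 30000 nM in this assay, at which 2 of the 3 values shown sit.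

Compound 4 `CCNc1cc(-c2ccc(NC(=O)Nc3ccc(OC)cc3)cc2F)ccn1` has not yet been measured. It carries fluoro in place of methoxy on an aromatic carbon, ortho to a 2-(ethylamino)pyridin-4-yl group (fluoro in place of methoxy on an aromatic carbon). Going by the values given here, no measured step makes this exact change. The closest replaces the other methoxy group with trifluoromethyl, giving an at least 1.1-fold lower number from compound 1 to compound 2 (0.06 log units; that floor lies within the scatter), and that floor lies within the scatter. The aryl swaps offer little more: a step that the two limits leave unreadable from compound 1 to compound 3 cannot be read, and an at least 1.1-fold higher number from compound 2 to compound 3 (0.06 log units; that floor lies within the scatter) also has a floor within the scatter. On this evidence, no step beyond the scatter is expected, and a result at the limit is quite likely.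

The estimated step is an at least 1.0-fold lower number from compound 1 to compound 4 (0.02 log units; that floor lies within the scatter). For compound 4 the expected value is 28000 nM, with an estimated range from 10000 nM to 60000 nM.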

Compound 4, half-maximal inhibitory concentration: 19600 nM
For compound 4 the middle estimate is 1.4-fold (0.15 log units) above the measured one, and the stated range covers the measured number.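

Compound 1, compound 2 and compound 3 all carry methoxy at this position, ortho to a 2-(ethylamino)pyridin-4-yl group, so compound 4 gives the first view of a change there. In this assay, replacing that methoxy with fluoro gives an at least 1.5-fold lower number from compound 1 to compound 4 (0.18 log units; that floor lies within the scatter). The value of compound 1 is a limit and not a number, so only a floor for this step can be read, and such limits are common in this set: the limit of > 30000 nM in this assay, at which 2 of the 4 values shown sit.

The compounds shown have only methoxy or fluoro here, so it remains open how a chloro, a hydroxyl or a simple hydrogen at this position would read. Also open, on these data alone, is whether fluoro would give a similar result alongside the 4-(trifluoromethyl)phenyl group of compound 2 or the 2,6-dimethylphenyl group of compound 3.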